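This account rests on a few compounds, and the source may have more. Where it says the series, first, only, none or still open, it means among the compounds named here.

Measured compounds:
- Compound 1, `COc1ccccc1C(=O)Nc1cccc(-c2oc3cc(-c4ccc(F)cc4)ccc3c(=O)c2O)c1`: 2100 nM
- Compound 2, `O=C(Nc1cccc(-c2oc3cc(-c4ccc(F)cc4)ccc3c(=O)c2O)c1)c1ccc(Br)cc1`: 24000 nM
- Compound 3, `Cc1cc(C(=O)Nc2cccc(-c3oc4cc(-c5ccc(F)cc5)ccc4c(=O)c3O)c2)ccc1F`: 7710 nM

All three share one core and differ only in the group on the carbonyl carbon of the amide. In a functional assay on MCF7 cells (Homo sapiens) for antiproliferative activity, read by CCK-8 assay, with a stated time of 72 h (a higher number here means a weaker inhibitor, a lower number a stronger inhibitor), compound 1 gives the lowest of the three numbers, with compound 3 nearest and compound 2 furthest. Swapping 2-methoxyphenyl for 4-bromophenyl gave an 11-fold higher number from compound 1 to compound 2 (1.06 log units; beyond the scatter), and swapping it for 4-fluoro-3-methylphenyl gave a 3.7-fold higher number from compound 1 to compound 3 (0.56 log units; beyond the scatter); between the two halogen-bearing groups the difference was a 3.1-fold lower number from compound 2 to compound 3 (0.49 log units; beyond the scatter).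

Compound 4, `O=C(Nc1cccc(-c2oc3cc(-c4ccc(F)cc4)ccc3c(=O)c2O)c1)c1ccc(Cl)nc1`, has not yet been measured in this assay. It differs from compound 1 in one place: 6-chloropyridin-3-yl in place of 2-methoxyphenyl on a carbonyl carbon. Both measured steps that replace 2-methoxyphenyl with a halogen-bearing six-membered ring raised the number beyond the scatter, by a modest to a large amount, so a weakening is expected here too, sitting between those two outcomes. The estimate for compound 4 is 9000 nM, with a range from 3000 nM to 27000 nM, a step of a 4.3-fold higher number from compound 1 to compound 4 (0.63 log units; beyond the scatter).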

Compound 4, half-maximal inhibitory concentration: 2890 nM
Beside the measured number, compound 4's estimate is 3.1-fold (0.49 log units) above it, and the stated range ends above it.
By their numbers in this assay, from the lowest: compounds 1 and 4 (each within the scatter of the next); then compound 3; then compound 2.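

In this assay, a halogen-bearing ring on this carbonyl carbon does not by itself separate a compound from the 2-methoxyphenyl parent: 6-chloropyridin-3-yl gives a 1.4-fold higher number from compound 1 to compound 4 (0.14 log units; within the scatter) and so stays level with it, unlike the two halogen-bearing rings measured earlier. The new ring also stands apart from those rings, with a 2.7-fold lower number from compound 3 to compound 4 (0.43 log units; beyond the scatter) and an 8.3-fold lower number from compound 2 to compound 4 (0.92 log units; beyond the scatter) showing that the identity of the ring at this position matters, not merely the presence of a halogen. Nothing measured here explains why these rings differ.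

The compounds shown do not separate the part played by the ring nitrogen from that of the chlorine, which unsubstituted pyridin-3-yl and 4-chlorophenyl could do. On these data alone, whether a non-aromatic group, such as cyclohexyl or an aminoalkyl chain, can take this place also remains open.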